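This account rests on a few compounds, and the source may have more. Where it says the series, first, only, none or still open, it means among the compounds named here.

In a functional assay on SF-295 cells (Homo sapiens) for inhibition, read by trypan blue exclusion, with a stated time of 48 h; on this read-out lower numbers stand for stronger inhibition and higher numbers for weaker inhibition:
- Compound 1 `CCCCCCC[C@H](O)C/C=C/CCC(=O)NCC(C)C`: > 100000 nM, a limit
- Compound 2 `CCCCCCC[C@H](O)C/C=C/CCC(=O)N1CCCCC1`: > 100000 nM, a limit

Among the measured compounds shown here, compound 2 has no numerical value, only this limit, and the one other measured compound also has only a limit. Compound 3 `CCCCCCC[C@H](O)C/C=C/CCC(=O)N1CCCC1` carries pyrrolidin-1-yl in place of piperidin-1-yl on a carbonyl carbon. For the measured compounds named here, the only measured step that bears on this change is a step that the two limits leave unreadable from compound 1 to compound 2, and its size cannot be read. The evidence is the limit of > 100000 nM in this assay, at which 2 of the 2 values shown sit. No step beyond the scatter is therefore expected in this assay. The estimated change is a number no higher from compound 2 to compound 3 (the limit leaves the size open). For compound 3 the expected value is 100000 nM, with an estimated range of 30000 nM to 200000 nM.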

Compound 3, half-maximal inhibitory concentration: > 100000 nM
Compound 3: no number, only a limit; the forecaster's own chance of this, stated with the estimate: 80%; the middle value lies on the limit itself.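

Among the compounds shown here, compound 1, compound 2 and compound 3 all stand only as limits in this assay, and no step among them can be read. The compounds shown leave open whether any group on the carbonyl carbon gives a measurable value.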